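Swapping Methylamino on a Carbonyl Carbon of Compound 1

The source may hold more compounds than are shown below. What is called first, only, known or untested is meant among the compounds shown, and "the series" means these compounds.

In a functional assay (strain AB) with Danio rerio as the target, read by microscopy, with a stated time of 1 h (on this read-out higher numbers stand for an effect only at larger amounts of compound and lower numbers for an effect already at smaller amounts), compound 1 `CCN1CCc2c(sc(NC(=O)Nc3ccc(Cl)cc3)c2C(=O)NC)C1` gives > 25000 nM, which is a limit of the assay and not a number. Compound 2 `NC(=O)c1c(NC(=O)Nc2ccc(Cl)cc2)sc2c1CCN(CCCNC(=O)CCc1c[nH]c3ccccc13)C2` gives a measured 100 nM in this assay, so compound 1 stands at the high end of the two values shown. Compound 3 `CCN1CCc2c(sc(NC(=O)Nc3ccc(Cl)cc3)c2C(=O)c2nc(C)no2)C1` keeps the core of compound 1 and differs in one group on a carbonyl carbon, with 3-methyl-1,2,4-oxadiazol-5-yl in place of methylamino on a carbonyl carbon. Within the data shown here, no measured step covers this change, so any expectation remains loose, and a result at the same limit would be no surprise. A modest move towards effects at smaller amounts is expected, and the estimated step is an at least 3.1-fold lower number from compound 1 to compound 3 (0.49 log units; beyond the scatter). For compound 3 the estimated value in this assay is 8000 nM, with an expected range of 1500 nM to 25000 nM.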

Compound 3, half-maximal effective concentration: > 25000 nM
Compound 3 gave a limit, no number (the forecaster's own chance of this, stated with the estimate: 45%); middle value at least 3.1-fold (0.49 log units) from the limit.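

No step can be read from compound 1 to compound 3, because both values are limits and not numbers: the limit of > 25000 nM in this assay, at which 2 of the 3 values shown sit. The compounds shown leave open whether 3-methyl-1,2,4-oxadiazol-5-yl in place of methylamino on a carbonyl carbon changes the effect at all.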